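Replacing a Chlorinated Chain with a Cyclopentyl Ring

A few compounds are considered here, and "the series" means these few. Any claim that something is new, unique, unknown or untested is made for them only; others in the source may bear on it.

Compound 1, `CC(C)c1ccccc1OS(=O)(=O)c1ccc(NC(=O)CCCl)cc1`: in a functional assay on HT-1080 cells (Homo sapiens) for antiproliferative activity, read by sulforhodamine B assay, with a stated time of 48 h (on this read-out lower numbers stand for stronger inhibition and higher numbers for weaker inhibition), compound 1 gives 6500 nM.
Compound 2, `CCNC(=O)Nc1ccc(S(=O)(=O)Oc2ccccc2C(C)C)cc1`: in this assay compound 2 gives 250 nM.
Compound 3, `CC(C)c1ccccc1OS(=O)(=O)c1ccc(NC(=O)NCCCCl)cc1`: in this assay compound 3 gives 2700 nM.

Among these three numbers compound 3 stands second highest. Compound 1 is its nearest neighbour, separated by the step of a 2.4-fold lower number from compound 1 to compound 3 (0.38 log units; beyond the scatter), while compound 2 is furthest away, separated by the step of an 11-fold higher number from compound 2 to compound 3 (1.03 log units; beyond the scatter).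

Compound 4, `CC(C)c1ccccc1OS(=O)(=O)c1ccc(NC(=O)NC2CCCC2)cc1`, differs from compound 3 by cyclopentyl in place of 3-chloropropyl on an amide-type nitrogen. Within the data shown here, two measured steps bear on this change. The step of an 11-fold higher number from compound 2 to compound 3 (1.03 log units; beyond the scatter) shows that putting a chlorine-bearing carbon onto the chain was costly, and compound 4 carries no chlorine at all. The step of a 26-fold lower number from compound 1 to compound 2 (1.41 log units; beyond the scatter) also shows that the urea with a short unchlorinated group gave the lowest number of the three. Among the measured compounds shown here, no measured step introduces a ring, so the size of the effect of the five-membered ring itself remains open. The expected step is therefore a 4.5-fold lower number from compound 3 to compound 4 (0.65 log units; beyond the scatter), towards a lower number. Compound 4 is estimated at 600 nM, with a range from 150 nM to 2500 nM.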

Compound 4, half-maximal inhibitory concentration: 3900 nM
Compound 4: middle estimate off by 6.5-fold (0.81 log units), on the low side; measured number outside the range, above it.
By their numbers in this assay, from the lowest: compound 2; then compounds 3, 4 and 1 (each within the scatter of the next, the first and the last beyond it).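

In this assay, compound 3 and compound 4 cannot be told apart (a 1.4-fold higher number from compound 3 to compound 4 (0.16 log units; within the scatter)), so the chlorine alone does not account for the high number of compound 3. Compound 2 remains clearly apart, as cyclopentyl in place of ethyl on the amide-type nitrogen gives a large step (a 16-fold higher number from compound 2 to compound 4 (1.19 log units; beyond the scatter)), while compound 4 also cannot be told apart from the amide compound 1 (a 1.7-fold lower number from compound 1 to compound 4 (0.22 log units; within the scatter)). Nothing available explains why the ring does not match the ethyl group.

A plain propyl chain on the same nitrogen would separate the effect of chain length from that of the chlorine, and a cyclopropyl ring would test whether a smaller ring comes closer to ethyl. On these data alone, whether a hydroxyl or an amine at the end of the chain is tolerated also stays open.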